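The source may report more compounds than this note shows. Statements on the series, on what has been measured and on what is new or still open speak of the compounds shown alone.

Of the compounds shown here, three built on one shared core have been tested in an ADME assay on HeLa cells (Homo sapiens) for cytotoxicity, read by MTT assay, with a stated time of 72 h; on this read-out lower numbers stand for higher toxicity in this test and higher numbers for lower toxicity in this test. Compound 1 `Fc1ccc(/C=N/c2sc3c(c2-c2nc4ccccc4s2)CCC3)cc1` gives 372 ug/mL. Compound 2 `Clc1ccccc1/C=N/c1sc2c(c1-c1nc3ccccc3s1)CCC2` gives 138 ug/mL. Compound 3 `Fc1ccc(/C=N/c2sc3c(c2-c2nc4ccccc4s2)CCCC3)cc1` gives 277 ug/mL, which places it second highest of the three numbers, nearest to compound 1 and furthest from compound 2, though both gaps lie within the scatter.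

Compound 4 `O=[N+]([O-])c1ccc(/C=N/c2sc3c(c2-c2nc4ccccc4s2)CCCC3)cc1` has not yet been measured. It differs from compound 3 by nitro in place of fluoro on an aromatic carbon, in words a nitro in place of fluoro on an aromatic carbon. Within the data shown here, no measured step shows this exact exchange. Among the measured compounds shown here, the only step at hand changes the same aryl group: a 2.7-fold lower number from compound 1 to compound 2 (0.43 log units; beyond the scatter). That step was modest, so a change on the same ring is expected to shift the number by a comparable amount, most likely downward, without going far beyond the scatter.

For compound 4 the number in this assay is expected to be 190 ug/mL, within a range from 90 ug/mL to 400 ug/mL. The expected step is a 1.5-fold lower number from compound 3 to compound 4 (0.16 log units; within the scatter).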

Compound 4, half-maximal cytotoxic concentration: 357 ug/mL
Compound 4: the middle estimate sits 1.9-fold (0.27 log units) below what was measured; low and high end bracket the measured number.
By their numbers in this assay, from the lowest: compounds 2, 3, 4 and 1 (each within the scatter of the next, the first and the last beyond it).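

In this assay, the exchange of 4-fluorophenyl for 4-nitrophenyl gives a 1.3-fold higher number from compound 3 to compound 4 (0.11 log units; within the scatter), so the two compounds cannot be told apart in this test. The earlier step, a 2.7-fold lower number from compound 1 to compound 2 (0.43 log units; beyond the scatter), changed both the halogen and where it sits on the ring, whereas here the place stays fixed, para to a large group, and a nitro with 3 heavy atoms and 2 hydrogen-bond acceptors replaces a single fluorine without a change beyond the scatter. Nothing available here explains this outcome.

Going by these compounds, it remains open whether an amine or a carboxylic acid in this same place would also stay within the scatter of compound 3. On these data alone, it is equally open whether 4-nitrophenyl would behave the same way on the core of compound 1.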